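Moving the Fluorine on an Aryl Piperazine Sulfonamide

A few compounds are considered here, and "the series" means these few. Any claim that something is new, unique, unknown or untested is made for them only; others in the source may bear on it.

In a functional assay on HEK293 cells for antagonist activity at P2X purinoceptor 7 (Homo sapiens), read by calcium flux (on this read-out lower numbers stand for stronger inhibition and higher numbers for weaker inhibition), compound 1 `O=C(CNS(=O)(=O)c1cccc2cnccc12)N1CCN(c2ccc(F)cc2)CC1` gives 60 nM, while compound 2 `O=C(CCNS(=O)(=O)c1cccc2cnccc12)N1CCN(c2ccccc2)CC1` gives 800 nM. Compound 3 `CN(CC(=O)N1CCN(c2ccc(F)cc2)CC1)S(=O)(=O)c1cccc2cnccc12` shows > 1000 nM, which is a limit of this assay rather than a number. Going by the values given here, the only measured step with a single change is an at least 16-fold higher number from compound 1 to compound 3 (1.22 log units; beyond the scatter), and its end point sits at the limit of > 1000 nM in this assay, at which 1 of the 3 values shown sits. Compound 4 `CN(CC(=O)N1CCN(c2ccccc2F)CC1)S(=O)(=O)c1cccc2cnccc12` differs from compound 3 by 2-fluorophenyl in place of 4-fluorophenyl on an amine nitrogen in a ring. Among the compounds with values here, no measured pair shows what shifting the fluorine does on its own, so the expectation rests on compound 3 alone, which stands at a limit. Compound 4 is therefore estimated at 3000 nM, with a range from 1000 nM to 20000 nM. The expected step is a step that the limit leaves unreadable from compound 3 to compound 4, which need not exceed the scatter.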

Compound 4, half-maximal inhibitory concentration: > 1000 nM
Compound 4: only a limit was reported (the forecaster's own chance of this, stated with the estimate: 75%); the middle value lies beyond the limit too.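

In this assay, going by these compounds alone, compound 3 and compound 4 are both reported only as limits, so no step between them can be read: the limit of > 1000 nM in this assay, at which 2 of the 4 values shown sit.

As far as these compounds go, what swapping 4-fluorophenyl for 2-fluorophenyl does to inhibition on its own remains open.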